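This account rests on a few compounds, and the source may have more. Where it says the series, first, only, none or still open, it means among the compounds named here.

Measured in a functional assay on HepG2 cells (Homo sapiens) for antiproliferative activity, read by CCK-8 assay, with a stated time of 48 h; on this read-out higher numbers stand for weaker inhibition and lower numbers for stronger inhibition:
Compound 1 `COc1ccc(/C=C\c2cc(OC)c(OC)c(OC)c2)cc1OCc1ccc(CN2CC[C@H](O)C2)cc1`: 6600 nM
Compound 2 `COc1ccc(/C=C\c2cc(OC)c(OC)c(OC)c2)cc1OCc1ccc(CNCCNC(C)=O)cc1`: 6100 nM

Only these two values exist so far, and compound 2 stands within the scatter of compound 1, so neither can be ranked over the other. Compound 3 `COc1ccc(/C=C\c2cc(OC)c(OC)c(OC)c2)cc1OCc1ccc(CN2CC[C@@H](O)C2)cc1` is still to be measured in this assay. The change leading to it from compound 2 is 3-hydroxypyrrolidin-1-yl in place of (2-acetamidoethyl)amino on a saturated chain carbon bound to an aromatic carbon. In words, 3-hydroxypyrrolidin-1-yl comes in place of (2-acetamidoethyl)amino on a saturated chain carbon bound to an aromatic carbon. Going by the values given here, the one measured step that bears on this is the same exchange run the opposite way, a 1.1-fold lower number from compound 1 to compound 2 (0.03 log units; within the scatter), and it lies within the scatter. Among the compounds with values here, compound 3 differs from compound 1 only in the sense of its one defined stereocentre, and no measured pair shows what inverting that centre does in this assay, so the range is kept wide. An estimated 1.1-fold higher number from compound 2 to compound 3 (0.03 log units; within the scatter) is therefore expected, which means no shift beyond the scatter. For compound 3 the estimated value is 6500 nM, with an expected range of 3000 nM to 14000 nM.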

Compound 3, half-maximal inhibitory concentration: 6200 nM
Beside the measured number, compound 3's estimate is 1.0-fold (0.02 log units) above it; low and high end bracket the measured number.
By their numbers in this assay, from the lowest: compounds 2, 3 and 1 (each within the scatter of the next).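

In this assay, going by these compounds alone, the earlier compounds left the sense of the stereocentre untested, and inverting it gives a 1.1-fold lower number from compound 1 to compound 3 (0.03 log units; within the scatter), so the two drawn configurations of the 3-hydroxypyrrolidin-1-yl group cannot be told apart in this read-out. The exchange of (2-acetamidoethyl)amino for 3-hydroxypyrrolidin-1-yl on a saturated chain carbon bound to an aromatic carbon, now read with the other configuration, gives a 1.0-fold higher number from compound 2 to compound 3 (0.01 log units; within the scatter), so the open chain and the ring in either configuration cannot be separated among these three compounds. The comparison of compound 1 with compound 3 speaks to configuration alone, with no other change mixed into it: the fact that compounds 1 and 3 differ only in the configuration as drawn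

The compounds shown leave open whether any group at this place would move the number beyond the scatter, for instance a plain pyrrolidine without the hydroxyl, a piperazine, a carboxylic acid or a longer chain carrying the acetamide. They also leave open whether the stereocentre would stay as silent with a different substitution on the shared core, or in any read-out other than this one.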